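The source may hold more compounds than are shown below. What is called first, only, known or untested is meant among the compounds shown, and "the series" means these compounds.

Four compounds built on one shared core are followed here in a physicochemical assay for lipophilicity, at pH 7.4; on this read-out higher numbers stand for higher lipophilicity and lower numbers for lower lipophilicity. Compound 1 `CNC(=O)c1cc(C(=O)NC2CC2)cn([C@H](C)c2ccccc2)c1=O` gives 3.4 in this assay. Compound 2 `CNC(=O)c1cccn(Cc2ccccc2)c1=O` gives 3, and compound 3 `CNC(=O)c1cc(C(=O)NC2CC2)cn(Cc2cccc(OC)c2)c1=O` gives 3. On these numbers compound 2 stands level with compound 3 at the digits shown, the two together being the lowest of the three values, with no change between them that exceeds the usual scatter; compound 1 lies furthest from compound 2, higher by an amount beyond the scatter.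

The step of interest leads from compound 2 to compound 4 `CNC(=O)c1cc(C(=O)NC2CCC2)cn(Cc2ccccc2)c1=O`, which has not yet been measured in this assay. The change is cyclobutylcarbamoyl in place of hydrogen on an aromatic carbon. Among the compounds with values here, no measured pair in this set differs in exactly this way, so the size of the step has to be judged from the surrounding values alone. A moderate rise in this assay is expected, since compound 1 gives 3.4 while compound 3 gives 3, both carrying more than compound 2 and neither falling lower. The expected step from compound 2 to compound 4 is a number 0.40 log units higher from compound 2 to compound 4 (beyond the scatter). For compound 4 the estimate in this assay is 3.4, within a range from 3 to 3.8.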

Compound 4, distribution coefficient: 3.8
Compound 4: middle estimate off by 0.40 log units, on the low side; measured number inside the range.
By their numbers in this assay, from the lowest: compounds 2 and 3 (each within the scatter of the next); then compound 1; then compound 4.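

Placing cyclobutylcarbamoyl on the aromatic carbon two atoms from the ring nitrogen, where compound 2 carries only hydrogen, gives the first direct reading of this change in this assay: the number moves a number 0.80 log units higher from compound 2 to compound 4 (beyond the scatter). Because that step lies beyond the usual scatter, this position is shown to be one where a substitution can clearly shift the read-out, at least with the benzyl group and the methylcarbamoyl group of these two compounds in place. Nothing available accounts for the rise, or tells how much of it belongs to the four-membered ring and how much to the carbamoyl part that carries it.

The compounds shown leave open how the number responds to other groups at this same carbon: a simple carboxylic acid, an amine or a plain methyl there would show whether any substituent moves it this way or whether the direction depends on the group. Also open, from the compounds shown here alone, is whether the same change gives a step of similar size when the benzyl group is replaced, as this single pair speaks for one setting only.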